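This account rests on a few compounds, and the source may have more. Where it says the series, first, only, none or still open, it means among the compounds named here.

In an ADME assay on L929 cells (Mus musculus) for cytotoxicity, read by resazurin assay, with a stated time of 48 h (a lower number here means that less compound is tolerated, a higher number that more compound is tolerated), compound 1 `C=Cn1c2ccc([N+](=O)[O-])cc2c(=O)n1Cc1ccccc1` gives 160000 nM, and compound 2 `C=CCn1c2ccc([N+](=O)[O-])cc2c(=O)n1Cc1ccccc1` gives 192000 nM. For the measured compounds named here, the one measured step between them is a 1.2-fold higher number from compound 1 to compound 2 (0.08 log units; within the scatter), with allyl in place of vinyl on an aromatic nitrogen. Compound 2 therefore stands level with compound 1, and the two numbers cannot be told apart. Compound 3 `C#CCn1c2ccc([N+](=O)[O-])cc2c(=O)n1Cc1ccccc1` differs from compound 2 in this same substituent: ethynyl in place of vinyl on a saturated chain carbon bound to an aromatic nitrogen. In words, this is ethynyl in place of vinyl on a saturated chain carbon bound to an aromatic nitrogen, which, cut one bond further out, reads allyl to propargyl. Going by the values given here, no measured step covers this exact change, so the only guide is the change at the same substituent, a 1.2-fold higher number from compound 1 to compound 2 (0.08 log units; within the scatter). On the strength of that small step, no shift beyond the scatter is expected in this assay, and no direction can be firmly assigned. The expected change is a 1.1-fold lower number from compound 2 to compound 3 (0.05 log units; within the scatter). For compound 3 the estimated value is 170000 nM, with an expected range from 80000 nM to 340000 nM.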

Compound 3, concentration lethal to 50% of the cells: 195000 nM
Estimate against measurement, compound 3: 1.1-fold (0.06 log units) below, and the stated range covers the measured number.
By their numbers in this assay, from the lowest: compounds 1, 2 and 3 (each within the scatter of the next).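

In this assay, ethynyl in place of vinyl on a saturated chain carbon bound to an aromatic nitrogen gives a 1.0-fold higher number from compound 2 to compound 3 (0.01 log units; within the scatter) and leaves the number where it was, while propargyl in place of vinyl on the aromatic nitrogen gives a 1.2-fold higher number from compound 1 to compound 3 (0.09 log units; within the scatter) and also stays within the scatter. The substituent at this place has now been read in three forms (vinyl, allyl and propargyl), and neither the exchange of a double bond for a triple bond nor the difference between vinyl and propargyl separates the numbers, so the three compounds cannot be told apart here. Nothing measured alongside these numbers explains why they stay together.

Whether a longer chain, an amine or a carboxylic acid at this place would carry the number beyond the scatter remains open, since all three substituents shown are small hydrocarbon groups. All three compounds also share the same core, so what a change elsewhere on it would do in this assay is equally unanswered.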